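Fluoro on the Benzoyl Ring and Cytotoxicity Tolerance

The source may hold more compounds than are shown below. What is called first, only, known or untested is meant among the compounds shown, and "the series" means these compounds.

Compound 1 `O=C(CSc1nc(Cc2c(F)cccc2Cl)cc(=O)[nH]1)c1ccccc1` and compound 2 `O=C(CSc1nc(Cc2c(F)cccc2Cl)cc(=O)[nH]1)c1ccc(F)cc1` share a core and differ by fluoro in place of hydrogen on an aromatic carbon. In an ADME assay on MT4 cells (Homo sapiens) for cytotoxicity, read by MTT assay (a higher number here means that more compound is tolerated, a lower number that less compound is tolerated), compound 1 reaches only a limit of the assay at > 13000 nM. In this assay compound 2 likewise reaches only a limit at > 61000 nM. The step that the two limits leave unreadable from compound 1 to compound 2 therefore cannot be read because the limit of > 13000 nM in this assay, at which 1 of the 3 values shown sits, and because of the limit of > 61000 nM in this assay, at which 1 of the 3 values shown sits.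

Compound 3 `CCc1c(Cc2c(F)cccc2F)nc(SCC(=O)c2ccccc2)[nH]c1=O` carries a different core; how its core differs from that of compound 1 is not broken down here. In this assay, going by the values given here, compound 3 gives 56000 nM, the only value of the three that is a number rather than a limit.

Compound 4 `CCc1c(Cc2c(F)cccc2F)nc(SCC(=O)c2ccc(F)cc2)[nH]c1=O` is compound 3 with fluoro in place of hydrogen on an aromatic carbon, the same change as that made from compound 1 to compound 2. Since that earlier step gave no readable size, the expectation for compound 4 rests on compound 3 alone at 56000 nM, and the step is expected to be a 1.1-fold higher number from compound 3 to compound 4 (0.03 log units; within the scatter). Compound 4 is estimated at 60000 nM, between 25000 nM and 130000 nM.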

Compound 4, half-maximal cytotoxic concentration: > 60000 nM
Compound 4 gave a limit, no number; the forecaster's own chance of this, stated with the estimate: 30%; the middle value lies on the limit itself.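

On the core of compound 3, fluoro in place of hydrogen gives an at least 1.0-fold higher number from compound 3 to compound 4 (0.02 log units; that floor lies within the scatter) in this assay, so the change shows no sign of a lower number there. As far as these compounds go, compound 4 stands at > 60000 nM, which is a limit of the assay and not a number, so the step is a floor and its true size remains unknown. The same change on the core of compound 1 cannot be read, so the data show that the step on one core is compatible with a limit on the other, but not that the change carries across the two cores with the same size.

The compounds shown hold only hydrogen or fluoro on the benzoyl ring, which leaves open how an amine or a carboxylic acid at that place would read in this assay. From the compounds shown here alone, it also remains open how the two cores compare when each carries the same benzoyl or (4-fluorophenyl)carbonyl group.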